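Phenyl to naphthalen-2-yl on the sulfonyl: compound 3 to compound 4

The source may hold more compounds than are shown below. What is called first, only, known or untested is meant among the compounds shown, and "the series" means these compounds.

Measured in a functional assay on MDA-MB-231 cells (Homo sapiens) for inhibition, read by CellTiter-Glo, with a stated time of 72 h; on this read-out higher numbers stand for lower toxicity in this test and lower numbers for higher toxicity in this test:
- compound 1 `CC1=C(CC(=O)N2CCN(c3ccncc3)CC2)c2cc(F)ccc2/C1=C\c1nc2ccccc2s1`: 7710 nM
- compound 2 `CC1=C(CC(=O)N(C)CCN(C)C(=O)[C@@H](N)C(C)C)c2cc(F)ccc2/C1=C\c1ccc([S+](C)[O-])cc1`: > 50000 nM (a limit of the assay)
- compound 3 `CC1=C(CC(=O)N(C)CCN(C)S(=O)(=O)c2ccccc2)c2cc(F)ccc2/C1=C\c1ccc([S+](C)[O-])cc1`: 12200 nM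

In this assay compound 3 gives 12200 nM and lies within the scatter of compound 1 at 7710 nM. Compound 2 gives > 50000 nM, which is a limit of the assay and not a number.

Compound 4 `CC1=C(CC(=O)N(C)CCN(C)S(=O)(=O)c2ccc3ccccc3c2)c2cc(F)ccc2/C1=C\c1ccc([S+](C)[O-])cc1` differs from compound 3 only on the sulfonyl group, with naphthalen-2-yl in place of phenyl on a sulfonyl sulfur. Within the data shown here, one measured step touches this part of the molecule: an at least 4.0-fold lower number from compound 2 to compound 3 (0.61 log units; beyond the scatter). Going by these compounds, that step starts from a limit, so its true size stays open, and it introduces the sulfonyl group rather than varying the group carried on it. Among the measured compounds shown here, no measured step changes that group, so the evidence for the size of the coming step is thin.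

The expected change is small, slightly towards a lower number and within the scatter, a 1.4-fold lower number from compound 3 to compound 4 (0.13 log units; within the scatter). This expectation is anchored on compound 3 at 12200 nM, with a wide range kept open. For compound 4 the estimated value is 9000 nM, expected to fall between 3500 nM and 25000 nM.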

Compound 4, half-maximal cytotoxic concentration: 32100 nM
Estimate against measurement, compound 4: 3.6-fold (0.55 log units) below; measured number outside the range, above it.
By their numbers in this assay, from the lowest: compounds 1 and 3 (each within the scatter of the next); then compound 4. At a limit, above all of these: compound 2.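

In this assay, the group carried on the sulfonyl sulfur makes a difference beyond the scatter: a 2.6-fold higher number from compound 3 to compound 4 (0.42 log units; beyond the scatter). Among these compounds, the only earlier step at this part of the molecule introduced the sulfonyl group, so this is the first reading of a change on the sulfonyl itself, and it runs towards lower toxicity in this test as one six-membered aromatic ring of carbon becomes two. Compound 4 at 32100 nM still gives a number. The room for further upward steps in this assay is bounded by compound 2, whose value is a limit: the limit of > 50000 nM in this assay, at which 1 of the 4 values shown sits.

Going by these compounds, a single step on the sulfonyl sets no trend, so it remains open whether the number follows the size of the aryl group, the second ring as such, or something particular to naphthalen-2-yl. Groups such as methyl, naphthalen-1-yl or a phenyl carrying an amine on the same sulfonyl sulfur would help separate these readings, and the same change on a different core would show whether the step carries over.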